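Swapping a chloro for methyl on a bis-amide sulfonamide

This account rests on a few compounds, and the source may have more. Where it says the series, first, only, none or still open, it means among the compounds named here.

Compound 1, `CCCCNC(=O)CCC(NS(=O)(=O)c1cc(Cl)ccc1Cl)C(=O)NCCCC`: 15.8%
Compound 2, `O=C(CCC(NS(=O)(=O)c1cc(Cl)ccc1Cl)C(=O)Nc1ccccc1)Nc1ccccc1`: 22.9%
Compound 3, `O=C(CCC(NS(=O)(=O)c1cc(Cl)ccc1Cl)C(=O)NCc1ccccc1)NCc1ccccc1`: 13.4%

All three were tested in a functional assay on IMR-32 cells (Homo sapiens) for cytotoxicity, read by MTT assay, tested at 60 ug/mL; on this read-out lower numbers stand for less inhibition and higher numbers for more inhibition at the one concentration tested (going by the name of the read-out). Compound 1 stands second highest of the three numbers, yet its gap to compound 3 and its gap to compound 2 both fall within the usual scatter, so the three compounds cannot be told apart on these numbers. The new compound 4, `CCCCNC(=O)CCC(NS(=O)(=O)c1cc(C)ccc1Cl)C(=O)NCCCC`, differs from compound 1 in one place: methyl in place of chloro on an aromatic carbon. Among the measured compounds shown here, no measured pair shows this change, so there is nothing to set its size by. The step from compound 1 to compound 4 is expected to be a number 0.8 percentage points lower from compound 1 to compound 4 (within the scatter), that is, none beyond the scatter. Compound 4 is therefore estimated at 15%, with a range from 5% to 27%.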

Compound 4, a percentage reported as inhibition, at one concentration (the size of the read-out at that concentration, not a potency): 18%
The estimate for compound 4 lay 3 percentage points below the measured number, within the range that was stated.
By their numbers in this assay, from the lowest: compounds 3, 1, 4 and 2 (each within the scatter of the next).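

Methyl in place of chloro on this aromatic carbon, para to a chloro group, now has a measured size: in this assay the step is a number 2.2 percentage points higher from compound 1 to compound 4 (within the scatter) and the two compounds cannot be told apart. This comes from a single pair, so it holds only for the core of compound 1. Nothing measured here bears on why the two compounds read alike.

Going by these compounds, whether an amine, a methoxy or a carboxylic acid on this carbon would give a step beyond the scatter remains open. So does whether the same swap would read alike on the core of compound 2 or compound 3.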